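A few compounds are considered here, and "the series" means these few. Any claim that something is new, unique, unknown or untested is made for them only; others in the source may bear on it.

Compound 1, `CCc1ccccc1NS(=O)(=O)c1ccc(N2CCNC2=O)cc1`, gives 240 nM in a functional assay on HT-29 cells (Homo sapiens) for antiproliferative activity, read by sulforhodamine B assay, with a stated time of 48 h; a higher number here means a weaker inhibitor, a lower number a stronger inhibitor.
Compound 2, `O=C1NCCN1c1ccc(S(=O)(=O)Nc2ccc(F)c(F)c2)cc1`, gives 350 nM in this assay.

Among the measured compounds shown here, compound 2 stands at the highest of the two numbers measured so far; its nearest neighbour is compound 1, and the step of a 1.5-fold higher number from compound 1 to compound 2 (0.16 log units; within the scatter) lies within the scatter, so the two cannot be told apart.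

Compound 3, `Cc1ccccc1NS(=O)(=O)c1ccc(N2CCNC2=O)cc1`, is the next compound to be measured. It differs from compound 2 in one place: 2-methylphenyl in place of 3,4-difluorophenyl on a sulfonamide nitrogen. For the measured compounds named here, only one measured step bears on this change, the one on the same sulfonamide nitrogen, a 1.5-fold higher number from compound 1 to compound 2 (0.16 log units; within the scatter), which did not rise above the scatter. The 2-methylphenyl group entering compound 3 is named much like the 2-ethylphenyl group of compound 1, whose number sits slightly under that of compound 2. A step in this assay of no more than the scatter is therefore expected, if anything toward a lower number.

Compound 3 is therefore estimated at 270 nM, within a range of 130 nM to 560 nM. This estimate means a step of a 1.3-fold lower number from compound 2 to compound 3 (0.11 log units; within the scatter), expected to stay within the scatter.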

Compound 3, half-maximal inhibitory concentration: 200 nM
The estimate for compound 3 lay 1.4-fold (0.13 log units) above the measured number, and the stated range covers the measured number.
By their numbers in this assay, from the lowest: compounds 3, 1 and 2 (each within the scatter of the next).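

On the sulfonamide nitrogen, the 2-methylphenyl group of compound 3 can now be compared in this assay with both earlier groups, giving a 1.8-fold lower number from compound 2 to compound 3 (0.24 log units; within the scatter) and a 1.2-fold lower number from compound 1 to compound 3 (0.08 log units; within the scatter) as its two steps. Neither exchanging 3,4-difluorophenyl for 2-methylphenyl nor shortening the chain of the 2-ethylphenyl group to a methyl moves the number beyond the scatter, so the three groups at this position cannot be told apart by this measurement. Nothing available offers a measured explanation for how closely these numbers agree.

As far as these compounds go, these compounds cover only carbon-only aromatic rings bearing fluorine, methyl or ethyl on this nitrogen, so it remains open whether a pyridine ring, or a phenyl ring carrying an amine or a carboxylic acid, would produce a step beyond the scatter. From the compounds shown here alone, it also remains open whether a longer chain, such as the propyl of a 2-propylphenyl group, would keep the number as close to those of compound 1 and compound 3 as the shorter chains do.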